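The source may hold more compounds than are shown below. What is called first, only, known or untested is meant among the compounds shown, and "the series" means these compounds.

Measured in an ADME assay on MDBK cells (Bos taurus) for cytotoxicity, read by MTT assay, with a stated time of 96 h; on this read-out higher numbers stand for lower toxicity in this test and lower numbers for higher toxicity in this test:
- Compound 1 `COc1ccc(-c2nc3cc(C(C)=O)ccc3[nH]2)c(OC)c1OC`: > 100000 nM, a limit
- Compound 2 `COc1ccc(-c2nc3cc(C(C)O)ccc3[nH]2)c(OC)c1OC`: 60000 nM
- Compound 3 `COc1ccc(-c2nc3cc(/C(C)=N/O)ccc3[nH]2)c(OC)c1`: > 100000 nM, a limit

Compound 3 gives > 100000 nM in this assay, which is a limit and not a number. Compound 3 thus stands at the limit of > 100000 nM in this assay, at which 2 of the 3 values shown sit. Compound 4 `COc1ccc(-c2nc3cc(/C(C)=N/O)ccc3[nH]2)c(OC)c1OC` has not yet been measured. It carries methoxy in place of hydrogen on an aromatic carbon, ortho to two methoxy groups (methoxy in place of hydrogen on an aromatic carbon).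

Among the measured compounds shown here, no measured step makes this same change. For the measured compounds named here, the only measured step is an at least 1.6-fold lower number from compound 1 to compound 2 (0.22 log units; that floor lies within the scatter). It swaps acetyl for 1-hydroxyethyl, which is a different change, so it offers little guidance here. The closest comparison is compound 1, which has the same three methoxy groups as compound 4 but an acetyl group in place of the oxime. Compound 1 gives > 100000 nM, which is also a limit.

With both neighbours of compound 4 at that limit, no step beyond the scatter is expected in this assay, and a second reading at the limit seems likely. The expected step is a number no higher from compound 3 to compound 4 (the limit leaves the size open). For compound 4 the estimated value is 100000 nM, with an expected range from 45000 nM to 200000 nM.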

Compound 4, half-maximal cytotoxic concentration: > 100000 nM
Compound 4: only a limit was reported; the forecaster's own chance of this, stated with the estimate: 70%; the middle value lies on the limit itself.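

In this assay compound 4 gives > 100000 nM, which is a limit of the assay and not a number, and so methoxy in place of hydrogen on this aromatic carbon, ortho to two methoxy groups, leaves the reading at the same limit that compound 3 already showed. Among the compounds shown here, with limits at both ends, the steps to compound 4 from compound 3 and from compound 1 cannot be read, so the size of any effect of this methoxy stays unknown; the only readable step is an at least 1.6-fold higher number from compound 2 to compound 4 (0.22 log units; that floor lies within the scatter), which swaps the 1-hydroxyethyl group for the oxime and stays within the usual scatter. The new result adds one more compound to the group at the top of the measurable range: the limit of > 100000 nM in this assay, at which 3 of the 4 values shown sit.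

Whether compound 3 and compound 4 truly differ cannot be told from these limits, as both could lie anywhere past the top of the tested range. Also open, going by these compounds, is how the cells would respond to an amine or a carboxylic acid in place of the oxime, or to a longer chain such as ethoxy in place of this methoxy.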